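This account rests on a few compounds, and the source may have more. Where it says the series, first, only, none or still open, it means among the compounds named here.

Series notes, step from compound 1 to compound 4.

Compound 1 `CN(C(=O)c1ccccc1)[C@@H](CCCNC(=N)N)C(=O)N[C@@H](CCCCN)C(=O)N[C@@H](C(N)=O)c1ccccc1` is the reference of the set. In an assay on isolated protein for inhibition of Trypsin (Homo sapiens), read by fluorescence, with a stated time of 15 min, tested at 50 uM (a higher number here means more inhibition at the concentration tested (going by the name of the read-out), a lower number less inhibition), compound 1 gives <= 5%. That value is a limit of the assay and not a number (the limit of <= 5% in this assay, at which 1 of the 3 values shown sits).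

Compound 2 `N=C(N)NCCC[C@H](NC(=O)C(=O)c1ccccc1)C(=O)N[C@@H](CCCCN)C(=O)N[C@@H](C(N)=O)c1ccccc1` carries (benzoylcarbonyl)amino where compound 1 has benzoyl(methyl)amino; in this assay compound 2 gives 33.5%, and the step is a number at least 28.5 percentage points higher from compound 1 to compound 2 (beyond the scatter). Compound 3 `CN(C(=O)c1ccccc1)[C@@H](CCCNC(=N)N)C(=O)N[C@@H](CCCCN)C(=O)N[C@@](C)(C(N)=O)c1ccccc1` has 1-carbamoyl-1-phenylethyl in place of carbamoyl(phenyl)methyl; in this assay compound 3 gives 10.9%, a step of a number at least 5.9 percentage points higher from compound 1 to compound 3 (that floor lies within the scatter).

Compound 4 `CN(C(=O)c1ccccc1)[C@@H](CCCNC(=N)N)C(=O)N[C@@H](CCCCN)C(=O)N[C@@H](C(N)=O)c1ccc(OCc2ccccc2)cc1` is still to be measured. Its difference from compound 1 is benzyloxy in place of hydrogen on an aromatic carbon. Neither measured step changes this aromatic ring. The step from compound 1 to compound 3 touches the same terminal group, but at a saturated carbon, and stays within the scatter; the step to compound 2 alters another part of the shared core. Among the measured compounds shown here, no measured step therefore bears directly on the change to compound 4, and no step beyond the scatter is expected, though a small rise cannot be excluded since compound 1 sits at the limit (the limit of <= 5% in this assay, at which 1 of the 3 values shown sits).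

The estimate for compound 4 in this assay is 10%, between 0% and 30%. The estimated step is a number at least 5 percentage points higher from compound 1 to compound 4 (that floor lies within the scatter), expected to lie within the scatter.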

Compound 4, a percentage reported as inhibition, at one concentration (the size of the read-out at that concentration, not a potency): <= 5%
Compound 4: only a limit was reported (the forecaster's own chance of this, stated with the estimate: 50%); middle value at least 5 percentage points from the limit.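

In this assay compound 4 gives <= 5%, a limit of the assay and not a number. Compound 1 gives <= 5%, also a limit. No step between compound 1 and compound 4 can be read, because both sit at the same limit: the limit of <= 5% in this assay, at which 2 of the 4 values shown sit.

The compounds shown leave open whether benzyloxy in place of hydrogen on this aromatic carbon changes inhibition at all.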